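Moving a methoxy group around the ring in a cytotoxicity series

The source may hold more compounds than are shown below. What is called first, only, known or untested is meant among the compounds shown, and "the series" means these compounds.

Measured compounds:
- Compound 1, `CC[C@H](Nc1cncc(-c2ccc(O)c(OC)c2)n1)c1ccccc1`: 10000 nM
- Compound 2, `CCCC(Nc1cncc(-c2ccc(O)c(OC)c2)n1)c1ccc(OC)cc1`: 3000 nM

Both compounds share the same core and were tested in a functional assay on PC-3 cells (Homo sapiens) for cytotoxicity, read by MTT assay, with a stated time of 72 h; on this read-out lower numbers stand for stronger inhibition and higher numbers for weaker inhibition. Compound 1 gives 10000 nM, while compound 2 gives 3000 nM, so compound 2 stands as the lower of the two numbers, and the gap between them is beyond the usual scatter. Compound 3, `CCCC(Nc1cncc(-c2ccc(O)c(OC)c2)n1)c1cccc(OC)c1`, has not yet been measured. It keeps the same atoms as compound 2, joined differently: 3-methoxyphenyl in place of 4-methoxyphenyl on a saturated chain carbon bound to a nitrogen on an aromatic ring and a saturated chain carbon. For the measured compounds named here, with only two measured compounds, no comparable change has been tested here, so no measured step guides the expectation. A shift of a single methoxy group on one ring often changes little, so a step near the scatter in either direction is expected, with a small chance of weakening. Compound 3 is estimated at 4000 nM, within 1500 nM to 10000 nM, which means an expected step of a 1.3-fold higher number from compound 2 to compound 3 (0.12 log units; within the scatter) in this assay.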

Compound 3, half-maximal inhibitory concentration: 10000 nM
Compound 3: middle estimate off by 2.5-fold (0.40 log units), on the low side; the range from low to high includes it.
By their numbers in this assay, from the lowest: compound 2; then compounds 1 and 3 (each within the scatter of the next).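

In this assay, the place of the methoxy group on this ring turns out to matter: 3-methoxyphenyl in place of 4-methoxyphenyl keeps the same atoms yet gives a 3.3-fold higher number from compound 2 to compound 3 (0.52 log units; beyond the scatter). For the compounds shown here, this is the first comparison here in which only one place changes, so it gives the first direct sign that the ring on this saturated chain carbon responds to where its substituent sits, although the step is modest and rests on a single pair. Nothing available gives a reason for this difference.

Still open, going by these compounds, is how a 4-chlorophenyl or a 4-hydroxyphenyl in place of the 4-methoxyphenyl of compound 2 would compare in this assay. The compounds shown also leave open what a longer chain on the same saturated carbon would do, with the 4-methoxyphenyl kept in place.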